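Trading a methyl for hydrogen on the core oxygen

A few compounds are considered here, and "the series" means these few. Any claim that something is new, unique, unknown or untested is made for them only; others in the source may bear on it.

Compound 2 `COc1cccc(/C=C/C(=O)c2c(OC)cc(OC)cc2OC)c1` gives 0.6% in a functional assay on HCT-116 cells (Homo sapiens), read by fluorescence and BrdU incorporation, with a stated time of 48 h, tested at 25 uM; on this read-out lower numbers stand for a stronger effect and higher numbers for a weaker effect at the one concentration tested. Among the three measured compounds it stands second highest: its nearest neighbour is compound 1 `COc1cc(OC)c(C(=O)/C=C/c2ccccc2SC)c(OC)c1`, which gives 0.5%, within the scatter, while the furthest is compound 3 `COc1cc(OC)c(C(=O)/C=C/c2ccc(Br)cc2)c(OC)c1`, which gives 68%. The measured steps, a number 0.1 percentage points higher from compound 1 to compound 2 (within the scatter), a number 67.5 percentage points higher from compound 1 to compound 3 (beyond the scatter) and a number 67.4 percentage points higher from compound 2 to compound 3 (beyond the scatter), all exchange the ring on the double-bonded chain carbon. Compound 4 `COc1cccc(/C=C/C(=O)c2c(O)cc(OC)cc2OC)c1` differs from compound 2 elsewhere: hydrogen in place of methyl on an oxygen on an aromatic ring. Among the measured compounds shown here, no measured step touches this oxygen, so there is nothing to set a size or direction from; the expectation is a step not clearly beyond the scatter, a number 4.4 percentage points higher from compound 2 to compound 4 (within the scatter). Compound 4 is therefore estimated at 5%, within 0% to 30%.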

Compound 4, a percentage reported as activity, at one concentration (the size of the read-out at that concentration, not a potency): 37%
Compound 4: the middle estimate sits 32 percentage points below what was measured; measured number outside the range, above it.
By their numbers in this assay, from the lowest: compounds 1 and 2 (each within the scatter of the next); then compound 4; then compound 3.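

The core oxygen is not a silent position: in this assay, going from methoxy to hydroxy there gives a number 36.4 percentage points higher from compound 2 to compound 4 (beyond the scatter) and so a weaker effect at the one concentration tested. The earlier compounds shown here showed changes only in the ring on the chain, whereas this shows that removing a single methyl from the shared core can also shift the read-out. Nothing available gives a reason for this step.

On these data alone, whether an ethyl or a longer chain on this oxygen would behave like methyl or like hydrogen remains open. So does the effect of the same exchange alongside the 4-bromophenyl or 2-(methylsulfanyl)phenyl ring.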